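The source may hold more compounds than are shown below. What is called first, only, known or untested is meant among the compounds shown, and "the series" means these compounds.

In a functional assay on HCT-15 cells (Homo sapiens) for cytotoxicity, read by CCK-8 assay, with a stated time of 4 days (a lower number here means a stronger inhibitor, a higher number a weaker inhibitor), compound 1 (`Oc1ccc(-c2cc(-c3ccccc3O)cc(-c3cccc(O)c3)n2)cc1`) gives 4850 nM and stands within the scatter of both other measured compounds: compound 2 (`Oc1cccc(-c2cc(-c3ccccc3O)cc(-c3cccc(O)c3)n2)c1`) gives 5150 nM and compound 3 (`Oc1ccc(-c2cc(-c3cccc(O)c3)cc(-c3cccc(O)c3)n2)cc1`) gives 3090 nM in the same read-out. The change to compound 4 (`Oc1ccc(-c2cc(-c3ccccc3O)cc(-c3ccc(O)cc3)n2)cc1`) is 4-hydroxyphenyl in place of 3-hydroxyphenyl on an aromatic carbon on the aromatic carbon next to the ring nitrogen. Within the data shown here, the nearest precedent is the swap of 3-hydroxyphenyl in place of 4-hydroxyphenyl, with a 1.1-fold higher number from compound 1 to compound 2 (0.03 log units; within the scatter) as its size. The swap of 3-hydroxyphenyl in place of 2-hydroxyphenyl gave a 1.6-fold lower number from compound 1 to compound 3 (0.20 log units; within the scatter) as its size. Neither step leaves the scatter, so no step beyond it is expected in this assay and the estimated 1.1-fold lower number from compound 1 to compound 4 (0.03 log units; within the scatter) remains small. For compound 4 the expected value is 4500 nM with an estimated range from 2400 nM to 8500 nM in this series.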

Compound 4, half-maximal inhibitory concentration: 1920 nM
For compound 4 the middle estimate is 2.3-fold (0.37 log units) above the measured one, outside the stated range (below it).
By their numbers in this assay, from the lowest: compounds 4, 3, 1 and 2 (each within the scatter of the next, the first and the last beyond it).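

Among these compounds, on the aromatic carbon next to the ring nitrogen, 4-hydroxyphenyl in place of 3-hydroxyphenyl gives a 2.5-fold lower number from compound 1 to compound 4 (0.40 log units; beyond the scatter), the first step beyond the scatter in this assay. The two groups have the same atoms and differ only in how they are joined, so the hydroxyl arrangement at this position can register in this read-out, though the step is modest. No measurement shown accounts for the step.

Still open, going by these compounds, is whether an amine or a methoxy group in place of this hydroxyl would keep the lower number. Also open, on these data alone, is whether the step recurs when the 2-hydroxyphenyl group is changed.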